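The source may report more compounds than this note shows. Statements on the series, on what has been measured and on what is new or still open speak of the compounds shown alone.

Measured in a physicochemical assay for solubility, read by spectrophotometry, measured as kinetic solubility, at pH 8, tested at 500 uM; a lower number here means a less soluble compound, a higher number a more soluble compound:
- compound 1 `CN1CCC(NC(=O)c2ccncc2Nc2cc(-c3ccc4ccn(C)c4c3)c3nccnc3c2)CC1`: 246 ug/mL
- compound 2 `CC(=O)N1CCC(NC(=O)c2ccncc2Nc2cc(-c3ccc4ccn(C)c4c3)c3nccnc3c2)CC1`: 213 ug/mL
- compound 3 `Cn1ccc2ccc(-c3cc(Nc4cnccc4C(=O)NC4CCNC(=O)C4)cc4nccnc34)cc21`: 242 ug/mL

Compound 3, at 242 ug/mL, stands level with the other two. Its value lies within the scatter of both, so the three cannot be ranked.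

Compound 4 `CN1CC(NC(=O)c2ccncc2Nc2cc(-c3ccc4ccn(C)c4c3)c3nccnc3c2)C1` has not yet been measured. It carries 1-methylazetidin-3-yl in place of 2-oxopiperidin-4-yl on an amide-type nitrogen.

Among the compounds with values here, three measured steps bear on this change, all of them changes within the group on that same nitrogen. Acetyl in place of methyl on the ring nitrogen gave a 1.2-fold lower number from compound 1 to compound 2 (0.06 log units; within the scatter). Putting in 2-oxopiperidin-4-yl for 1-methylpiperidin-4-yl gave a 1.0-fold lower number from compound 1 to compound 3 (0.01 log units; within the scatter), and putting it in for 1-acetylpiperidin-4-yl gave a 1.1-fold higher number from compound 2 to compound 3 (0.06 log units; within the scatter). All three steps are small. None of them tests a four-membered ring, however, so the evidence is indirect.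

In this assay, no step beyond the scatter is therefore expected, in either direction. The estimated change is a 1.1-fold lower number from compound 3 to compound 4 (0.03 log units; within the scatter). For compound 4 the expected value is 225 ug/mL, with an estimated range of 165 ug/mL to 255 ug/mL.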

Compound 4, solubility: 170 ug/mL
Compound 4: middle estimate off by 1.3-fold (0.12 log units), on the high side; measured number inside the range.
By their numbers in this assay, from the lowest: compounds 4, 2, 3 and 1 (each within the scatter of the next).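

In this assay, the first four-membered ring on this amide-type nitrogen, 1-methylazetidin-3-yl, gives a 1.4-fold lower number from compound 3 to compound 4 (0.15 log units; within the scatter) and a 1.3-fold lower number from compound 2 to compound 4 (0.10 log units; within the scatter) and also a 1.4-fold lower number from compound 1 to compound 4 (0.16 log units; within the scatter), so it stays within the scatter of all three six-membered groups. The earlier compounds shown here varied only what was attached to a six-membered ring or what that ring contained, whereas this change alters the ring size itself and removes the hydrogen-bond donor and the double bond of 2-oxopiperidin-4-yl, yet the four numbers still cannot be ranked. Nothing measured here offers an explanation for these small steps.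

The compounds shown all carry a saturated ring containing one nitrogen on the amide-type nitrogen, so a five-membered pyrrolidine ring, an open chain such as 2-(dimethylamino)ethyl, and a group bearing a carboxylic acid all remain open. Also open, on these data alone, is whether a ring without the methyl group, such as azetidin-3-yl itself, would stay within the scatter of these four compounds.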